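A few compounds are considered here, and "the series" means these few. Any claim that something is new, unique, unknown or untested is made for them only; others in the source may bear on it.

Compound 1, `CCC(=O)NCc1cncc(N2C(=O)c3ccc(Cl)cc3C2(C)C)c1`, gives 282 nM in an assay on cells for inhibition of cytochrome P450 11B2, mitochondrial (Homo sapiens), read by HTRF; on this read-out lower numbers stand for stronger inhibition and higher numbers for weaker inhibition.
Compound 2, `CC[C@@H]1c2cc(Cl)ccc2C(=O)N1c1cncc2c1CCC[C@H]2NC(C)=O`, gives 7 nM in this assay.
Compound 3, `CC(=O)NCc1cncc(N2C(=O)c3ccc(Cl)cc3C2(C)C)c1`, gives 59 nM in this assay.

Compound 2 has the lowest number of the three; its nearest neighbour is compound 3 and its furthest is compound 1, both gaps lying beyond the usual scatter. The difference between the core of compound 1 and the core of compound 2 is not broken down here. Within the first core, the step of a 4.8-fold lower number from compound 1 to compound 3 (0.68 log units; beyond the scatter) belongs to the change (hydrogen in place of methyl on a saturated chain carbon bound to a carbonyl carbon).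

Compound 4, `CC(=O)N[C@@H]1CCCc2c1cncc2N1C(=O)c2ccc(Cl)cc2[C@H]1C`, has not yet been measured in this assay. It differs from compound 2 by hydrogen in place of methyl on a saturated chain carbon bound to a saturated ring carbon. For the measured compounds named here, this is the same kind of change as the one from compound 1 to compound 3, but not the same: there the place is a saturated chain carbon bound to a carbonyl carbon, here it is a saturated chain carbon bound to a saturated ring carbon. Because the earlier step of a 4.8-fold lower number from compound 1 to compound 3 (0.68 log units; beyond the scatter) sat at a different place, only a smaller change is expected here, and because compound 2 already gives 7 nM, the step from compound 2 to compound 4 is estimated at a 1.4-fold lower number from compound 2 to compound 4 (0.15 log units; within the scatter). Compound 4 is thus expected to give about 5 nM, between 1.5 nM and 15 nM.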

Compound 4, half-maximal inhibitory concentration: 130 nM
Compound 4: the middle estimate sits 26-fold (1.41 log units) below what was measured; the whole stated range lies below it.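

In this assay, cutting the ethyl to methyl on the saturated ring carbon of compound 2 gives a 19-fold higher number from compound 2 to compound 4 (1.27 log units; beyond the scatter), a large weakening of inhibition. The same kind of change therefore does not carry from one core to the other in this series, and even its direction is reversed: the same change on two cores in this assay, a 4.8-fold lower number (0.68 log units; beyond the scatter) from compound 1 to compound 3 and a 19-fold higher number (1.27 log units; beyond the scatter) from compound 2 to compound 4, 89-fold (1.95 log units) apart, beyond the scatter of two such steps. This pair of steps does not show whether the reversal belongs to the place of the change, a saturated chain carbon bound to a carbonyl carbon in one case and to a saturated ring carbon in the other, or to the rest of the core, as the two steps differ in both.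

The compounds shown leave open whether exchanging the acetyl group of compound 2 for a propionyl group would follow the step seen on the other core, which would help to separate place from core. They also leave open how a longer chain such as propyl, or an amine, would fare in place of the ethyl of compound 2.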